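The compounds below may be only part of what the source reports. "The series", "measured", "known", "first", "only" and "open" are said of these compounds alone.

Compound 1 `Cc1cc(-c2cc(Cl)cc(Cl)c2)cc(C)c1Nc1ccnc(Nc2ccc(C#N)cc2)n1` and compound 2 `Cc1cc(-c2ccccc2F)cc(C)c1Nc1ccnc(Nc2ccc(C#N)cc2)n1` share one core and differ only in the pendant aryl group. In an ADME assay on MT4 cells (Homo sapiens) for cytotoxicity, read by MTT assay, with a stated time of 4 days (on this read-out higher numbers stand for lower toxicity in this test and lower numbers for higher toxicity in this test), compound 1 gives 4290 nM, and compound 2 gives 2120 nM; the step of a 2.0-fold lower number from compound 1 to compound 2 (0.31 log units; beyond the scatter) goes with 2-fluorophenyl in place of 3,5-dichlorophenyl on an aromatic carbon. Compound 2 thus holds the lowest of the two numbers, with compound 1 as its nearest neighbour at a higher number.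

Compound 3 `COc1ccccc1-c1cc(C)c(Nc2ccnc(Nc3ccc(C#N)cc3)n2)c(C)c1` is the next member: methoxy in place of fluoro on an aromatic carbon. Going by the values given here, no measured step exchanges fluoro for methoxy; the single step in hand, a 2.0-fold lower number from compound 1 to compound 2 (0.31 log units; beyond the scatter), concerns a different aryl group and gives no direct guide, so no movement beyond the scatter is assumed. For compound 3 the expected step is a 1.2-fold higher number from compound 2 to compound 3 (0.07 log units; within the scatter), nothing beyond the scatter. The value expected for compound 3 is 2500 nM, within a range of 1000 nM to 6500 nM.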

Compound 3, half-maximal cytotoxic concentration: 940 nM
The estimate for compound 3 lay 2.7-fold (0.42 log units) above the measured number; measured number below the stated range.
By their numbers in this assay, from the lowest: compound 3; then compound 2; then compound 1.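

In this assay, methoxy in place of fluoro on an aromatic carbon, ortho to a large group, gives a 2.3-fold lower number from compound 2 to compound 3 (0.35 log units; beyond the scatter), so an exchange at this single position moves the number beyond the scatter, towards higher toxicity in this test. Measured against the 3,5-dichlorophenyl group, the 2-methoxyphenyl group gives a 4.6-fold lower number from compound 1 to compound 3 (0.66 log units; beyond the scatter), the widest spread among the three compounds, with both 2-substituted phenyl groups lying at lower numbers than the 3,5-dichlorophenyl group. Nothing available explains why methoxy and fluoro differ here.

The compounds shown leave open whether the change follows the oxygen or the added carbon of methoxy, which a hydroxyl or an ethoxy group at this place would help to separate. They also leave open whether methoxy elsewhere on the pendant ring gives a similar step.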